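This account rests on a few compounds, and the source may have more. Where it says the series, first, only, none or still open, it means among the compounds named here.

Measured so far:
compound 1 `COc1ccc(NC(=O)CN2CCN(S(=O)(=O)N3CCC(C)CC3)CC2)cc1`: > 10000 nM
compound 2 `COc1ccc(Cl)cc1NC(=O)CN1CCN(S(=O)(=O)N2CCN(C(=O)N3CCC(C)(C)CC3)CC2)CC1`: 9000 nM

In an assay on HEK293 cells for activation of potassium channel subfamily T member 1 (Homo sapiens), read by thallium flux (a lower number here means that less compound is needed, a higher number that more compound is needed for the effect), compound 1 gives only a limit, not a number, sitting at the limit of > 10000 nM in this assay, at which 1 of the 2 values shown sits. Its exact position among the measured compounds is thus unknown. Compound 2 gives a measured value of 9000 nM in this assay. Compound 3 `CC1CCN(S(=O)(=O)N2CCN(CC(=O)Nc3ccccc3)CC2)CC1` differs from compound 1 in a single place: hydrogen in place of methoxy on an aromatic carbon. Within the data shown here, no measured step of this kind is available, so no shift beyond the usual scatter in this assay is expected in either direction. Compound 3 is thus expected near 15000 nM, with a likely range from 6000 nM to 40000 nM, and the expected step is a step that the limit leaves unreadable from compound 1 to compound 3.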

Compound 3, half-maximal effective concentration: > 10000 nM
Compound 3: a limit, no number (the forecaster's own chance of this, stated with the estimate: 70%); the middle value is on the limit's open side.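

In this assay, compound 1 and compound 3 each give only a limit, not a number, so the step between them cannot be read. Going by these compounds, whether hydrogen in place of methoxy shifts the concentration needed, in either direction, stays open.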